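Ring size at the chain end: pyrrolidine to piperidine

The compounds below may be only part of what the source reports. "The series", "measured", "known", "first", "only" and "open" are said of these compounds alone.

Measured so far:
compound 1, `COc1cc2c(Oc3ccc(NC(=O)c4cc(-c5ccc(F)cc5)ccn4)cc3F)ccnc2cc1OCCCN1CCCCC1`, in a functional assay on A549 cells (Homo sapiens) for cytotoxicity, read by MTT assay, with a stated time of 72 h (on this read-out higher numbers stand for weaker inhibition and lower numbers for stronger inhibition), gives 10100 nM;
compound 2, `COc1cc2c(Oc3ccc(NC(=O)c4cc(-c5ccccc5)ccn4)cc3F)ccnc2cc1OCCCN1CCCC1`, in this assay gives 1580 nM.

Compound 2 has the lowest number of the two, and compound 1, which differs from it in more than one place, lies beyond the scatter above it. Compound 3, `COc1cc2c(Oc3ccc(NC(=O)c4cc(-c5ccccc5)ccn4)cc3F)ccnc2cc1OCCCN1CCCCC1`, carries the change (piperidin-1-yl in place of pyrrolidin-1-yl on a saturated chain carbon, three bonds along the chain from an oxygen on an aromatic ring). For the measured compounds named here, no single-change step of this kind has been measured here, so no direction is established; the author expects a small rise in the number, not far beyond the scatter, with a 2.0-fold higher number from compound 2 to compound 3 (0.31 log units; beyond the scatter). Compound 3 is therefore estimated at 3200 nM, within 1000 nM to 10000 nM.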

Compound 3, half-maximal inhibitory concentration: 1800 nM
The estimate for compound 3 lay 1.8-fold (0.25 log units) above the measured number; measured number inside the range.
By their numbers in this assay, from the lowest: compounds 2 and 3 (each within the scatter of the next); then compound 1.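

In this assay, piperidin-1-yl in place of pyrrolidin-1-yl on this saturated chain carbon gives a 1.1-fold higher number from compound 2 to compound 3 (0.06 log units; within the scatter), so the two rings cannot be told apart at this position. Hydrogen in place of fluoro on an aromatic carbon gives a 5.6-fold lower number from compound 1 to compound 3 (0.75 log units; beyond the scatter), so in this pair, removing the fluoro group produces a step beyond the scatter. Nothing available gives a reason for either step. Going by these compounds, whether morpholin-4-yl or dimethylamino at the chain end would read like these two rings remains open. So does whether chloro or methoxy on that aromatic carbon would read like fluoro.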